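Benzyl to 4-nitrophenyl: an expected cytotoxicity value

The source may hold more compounds than are shown below. What is called first, only, known or untested is meant among the compounds shown, and "the series" means these compounds.

Compound 2 `CCn1cc(-c2nnc(Cc3ccccc3)o2)c(=O)c2cc(F)c(N3CCNCC3)cc21` in a functional assay on A549 cells (Homo sapiens) for cytotoxicity, read by MTT assay (a lower number here means a stronger inhibitor, a higher number a weaker inhibitor), gives 118 ug/mL. Of the two numbers shown, this is the highest, but its only neighbour, compound 1 `CCn1cc(-c2nnc(-c3ccccc3)o2)c(=O)c2cc(F)c(N3CCNCC3)cc21`, stands within the scatter: compound 1 gives 112 ug/mL. Among the measured compounds shown here, the one measured step, a 1.1-fold higher number from compound 1 to compound 2 (0.02 log units; within the scatter), is within the scatter.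

Compound 3 `CCn1cc(-c2nnc(-c3ccc([N+](=O)[O-])cc3)o2)c(=O)c2cc(F)c(N3CCNCC3)cc21` has not yet been measured. It differs from compound 2 by 4-nitrophenyl in place of benzyl on an aromatic carbon. For the measured compounds named here, the single measured step bears on it only loosely: exchanging phenyl for benzyl left the number within the scatter, which suggests the group at this place tolerates change without a shift in this assay. Nothing measured speaks to the nitro group itself, so the range stays wide. The step of a 1.1-fold lower number from compound 2 to compound 3 (0.05 log units; within the scatter) is expected to be none beyond the scatter. Compound 3 is therefore estimated to give 105 ug/mL in this assay, between 50 ug/mL and 220 ug/mL.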

Compound 3, half-maximal inhibitory concentration: 74.3 ug/mL
Beside the measured number, compound 3's estimate is 1.4-fold (0.15 log units) above it, within the range that was stated.
By their numbers in this assay, from the lowest: compounds 3, 1 and 2 (each within the scatter of the next).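

Among the compounds shown here, with the nitro group, this assay gives the first reading on a substituent carried on the phenyl ring: nitro in place of hydrogen gives a 1.5-fold lower number from compound 1 to compound 3 (0.18 log units; within the scatter). The exchange of benzyl for 4-nitrophenyl gives a 1.6-fold lower number from compound 2 to compound 3 (0.20 log units; within the scatter), so phenyl, benzyl and 4-nitrophenyl have all been tolerated on the aromatic carbon of the five-membered ring without any step beyond the scatter, even though the entering group brings two hydrogen-bond acceptors that benzyl lacks. Nothing available accounts for these values or explains why the steps stay so small.

What the compounds shown leave open is whether an amine or a carboxylic acid in place of the nitro group would give a step beyond the scatter. As far as these compounds go, it also remains open whether a longer chain in place of benzyl would do so.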